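Working notes: from compound 1 to its anilide, compound 4

The compounds below may be only part of what the source reports. "The series", "measured", "known", "first", "only" and "open" are said of these compounds alone.

compound 1 `CC(=O)SCCC(CCCCC(=O)O)SC(C)=O`: 10.3%
compound 2 `O=C(CCCCC1CCSS1)Nc1ccc(Cl)cn1`: "not active" (no number reported)
compound 3 `O=C(CCCCC(S)CCS)Nc1cccc2ccccc12`: "not active" (no number reported)

Among the compounds with values here, in a functional assay on Bel-7402 cells (Homo sapiens) for inhibition, read by MTT assay, with a stated time of 24 h, tested at 0.1 ug/mL (a higher number here means more inhibition of growth at the concentration tested, a lower number less inhibition of growth), compound 1 gives 10.3%, the only number. Compound 2 and compound 3 are amides, but neither has a number to compare with it. Compound 4 `CC(=O)SCCC(CCCCC(=O)Nc1ccccc1)SC(C)=O` has anilino in place of hydroxy on a carbonyl carbon. Within the data shown here, no measured pair shows the size of this change. Compound 2 at "not active" (no number reported) and compound 3 at "not active" (no number reported) give only weak grounds to expect a rise, so no step beyond the scatter is expected in this assay. The estimated change is a number 0.3 percentage points lower from compound 1 to compound 4 (within the scatter). For compound 4 the expected value is 10%, with an estimated range of 0% to 25%.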

Compound 4, percent growth inhibition at one concentration: "not active" (no number reported)
For compound 4 the study gives words and no number; no gap can be computed for the estimate.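

In this assay, within the data shown here, no step from compound 1 to compound 4 can be read, as compound 4 has words and no number. No supporting evidence bears on this result. The compounds shown leave open how far anilino in place of hydroxy on a carbonyl carbon shifts growth inhibition.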